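The source may report more compounds than this note shows. Statements on the series, on what has been measured and on what is new or still open speak of the compounds shown alone.

Measured so far in an ADME assay on Huh-5-2 cells (Homo sapiens) for cytotoxicity, read by MTT assay, with a stated time of 72 h; on this read-out higher numbers stand for lower toxicity in this test and lower numbers for higher toxicity in this test:
Compound 1 `Cc1ccc(N2C(=O)/C(=C\c3ccccc3)C=C2c2ccccc2)c(Br)c1`: > 240000 nM
Compound 2 `COc1ccc(/C=C2/C=C(c3ccccc3)N(c3ccccc3)C2=O)cc1`: 97200 nM

Compound 1 shows > 240000 nM, which is a limit of the assay and not a number. Going by the values given here, that makes compound 2, at 97200 nM, the only true number available in this assay, and so the one firm starting point for what follows.

Compound 3 `O=C1/C(=C\c2ccc(-c3ccccc3)cc2)C=C(c2ccccc2)N1c1ccccc1` keeps the core of compound 2 and alters a single group: phenyl in place of methoxy on an aromatic carbon. Among the compounds with values here, no pair of measured compounds shows a change of this kind, so there is no direct precedent for its size. The expectation is therefore a step no larger than the usual scatter of repeated measurements, with no firm direction. Compound 3 could also be reported only as a limit, as compound 1 was. The estimated step is a 1.1-fold lower number from compound 2 to compound 3 (0.03 log units; within the scatter). For compound 3 the estimated value is 90000 nM, with an expected range of 30000 nM to 240000 nM.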

Compound 3, half-maximal cytotoxic concentration: 156000 nM
Beside the measured number, compound 3's estimate is 1.7-fold (0.24 log units) below it, within the range that was stated.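

With phenyl in place of methoxy on an aromatic carbon, this assay gives its first step that can be read between two compounds: a 1.6-fold higher number from compound 2 to compound 3 (0.21 log units; within the scatter). The change is not a small one on paper, since it swaps a methoxy of 2 heavy atoms for a phenyl of 6 and adds a six-membered aromatic ring of carbon only, on a position para to a large group. Even so, the two numbers cannot be told apart in this test, so on this one pair the position accepts either group without a readable change in the read-out.

From the compounds shown here alone, whether that holds for a group of a different kind at the same position, such as an amine, a carboxylic acid or a longer chain, remains open, as one pair cannot show a trend. Compound 1 stands only as a limit of the assay and not as a number, and it differs from compound 2 in more than one place, so it cannot extend this comparison: the limit of > 240000 nM in this assay, at which 1 of the 3 values shown sits.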